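The source may report more compounds than this note shows. Statements on the series, on what has been measured and on what is new or still open speak of the compounds shown alone.

Compound 1 `COc1cc(C2=C(c3cc(C)c(OC)c(C)c3)C(O)CC2=O)cc(OC)c1OC` was examined in an ADME assay on HEK293 cells (Homo sapiens) for cytotoxicity, read by MTT assay, with a stated time of 72 h; a higher number here means a weaker inhibitor, a lower number a stronger inhibitor. In this assay compound 1 gives > 100 ug/mL, which is a limit of the assay rather than a number. Two further members of the same series were run alongside it. Compound 2 `COc1ccc(C2=C(c3cc(OC)c(OC)c(OC)c3)CC(O)C2=O)cc1N` carries an amino group on one aryl ring of the shared core; in this assay compound 2 gives > 100 ug/mL, again a limit. Compound 3 `CCOC(=O)COc1ccc(C2=C(c3cc(OC)c(OC)c(OC)c3)C(=O)CC2O)cc1` bears an ester-containing side chain on one aryl ring; in this assay compound 3 gives > 100 ug/mL, which is also a limit. Compound 1 therefore stands exactly where every other value shown stands, at the limit of > 100 ug/mL in this assay, at which 3 of the 3 values shown sit, and nothing separates the three compounds on the numbers available.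

Compound 4 `COc1cc(C2=C(c3cc(C)c(OC)c(C)c3)C(O[SiH2]C(C)(C)C)CC2=O)cc(OC)c1OC` has not yet been measured. It differs from compound 1 in a single place: a group of 5 heavy atoms (4 carbon, 1 silicon; no ring) in place of a hydrogen atom, on an oxygen on a saturated carbon. Going by the values given here, no step between measured compounds exists to show how a change of this kind moves the read-out, so the expectation rests on the limits alone. With all three measured values sitting at the limit of > 100 ug/mL in this assay, at which 3 of the 3 values shown sit, the step from compound 1 to compound 4 is expected to be a step that the limit leaves unreadable from compound 1 to compound 4, that is, no shift beyond the scatter. Compound 4 is accordingly expected to give 150 ug/mL in this assay, within a range from 60 ug/mL to 400 ug/mL, and most likely to be reported once more only as a limit.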

Compound 4, half-maximal inhibitory concentration: 29 ug/mL
Beside the measured number, compound 4's estimate is 5.2-fold (0.71 log units) above it, outside the stated range (below it).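

In this assay, the oxygen on a saturated carbon proves to be a place where a change can be read: replacing its hydrogen atom with a group of 5 heavy atoms (4 carbon, 1 silicon; no ring) gives an at least 3.4-fold lower number from compound 1 to compound 4 (0.53 log units; beyond the scatter). The earlier compounds shown here could not show this, as none of them gave more than a limit. Compound 4 gives a true number, 29 ug/mL, and so offers the first measured value in the series shown. The step can be stated only as a minimum, and its true size stays unknown, because the value of compound 1 is a limit of the assay rather than a number: the limit of > 100 ug/mL in this assay, at which 3 of the 4 values shown sit.

The compounds shown leave open whether the silicon matters or whether any substituent on this oxygen would move the read-out in the same way, as a methyl ether, an acetyl ester or a purely carbon chain of similar size might. They also leave open whether the same silicon-bearing group would have a comparable effect on the cores of compound 2 and compound 3, which carry an amino group and an ester-containing side chain on one aryl ring.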